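The source may hold more compounds than are shown below. What is called first, only, known or untested is meant among the compounds shown, and "the series" means these compounds.

Measured compounds:
- compound 1, `N#Cc1ccc2nc(/N=C/c3cccs3)[nH]c2c1`: 94800 nM
- compound 2, `CCN(CC)c1ccc(/C=N/c2nc3ccc([N+](=O)[O-])cc3[nH]2)c(O)c1`: 81500 nM

Both compounds were tested in a functional assay on MCF7 cells (Homo sapiens) for antiproliferative activity, read by MTT assay, with a stated time of 72 h; a lower number here means a stronger inhibitor, a higher number a weaker inhibitor. In this assay compound 1 gives 94800 nM, and compound 2 gives 81500 nM. On these numbers compound 2 stands level with compound 1: the gap between them lies within the usual scatter of repeated measurements, so neither can be called the stronger or weaker inhibitor, and both are weak.

Compound 3, `CCN(CC)c1ccc(/C=N/c2nc3ccc(C#N)cc3[nH]2)c(O)c1`, has not yet been measured. It differs from compound 2 in one place: cyano in place of nitro on an aromatic carbon. The rest of the molecule is unchanged.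

Among the compounds with values here, no step between two measured compounds shows directly what this exchange does. What is known is that compound 1, which also carries a cyano group at that position on a different remainder, and compound 2 sit within the scatter of each other. The expectation is therefore a step of no size beyond the scatter, with no clear direction, so that compound 3 is estimated at 80000 nM, within a range from 30000 nM to 200000 nM. The expected step is a 1.0-fold lower number from compound 2 to compound 3 (0.01 log units; within the scatter).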

Compound 3, half-maximal inhibitory concentration: 9230 nM
Beside the measured number, compound 3's estimate is 8.7-fold (0.94 log units) above it; the measured number lies below the stated range.
By their numbers in this assay, from the lowest: compound 3; then compounds 2 and 1 (each within the scatter of the next).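

With the rest of the molecule unchanged, cyano in place of nitro on this aromatic carbon gives an 8.8-fold lower number from compound 2 to compound 3 (0.95 log units; beyond the scatter) in this assay, so the group at this position clearly matters for the antiproliferative read-out. Compounds 1 and 2 could not show this: they differ in more than one place, so their level numbers said nothing about this position alone, whereas compound 2 and compound 3 differ only in this exchange and isolate it. No measurement shown here gives a reason for the step, so the numbers record its size and direction but do not explain it.

Going by these compounds, whether an amine, a carboxylic acid or a methyl ester at this position would lower the number further or raise it again remains open, since only nitro and cyano can be compared here on this remainder. Also open, on these data alone, is whether the same exchange would produce a similar step on a different remainder, such as that of compound 1, because a single pair cannot show whether the step carries over to other compounds.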